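A few compounds are considered here, and "the series" means these few. Any claim that something is new, unique, unknown or untested is made for them only; others in the source may bear on it.

Series in a functional assay on HCT-116 cells (Homo sapiens) for antiproliferative activity, read by MTT assay, with a stated time of 48 h; on this read-out lower numbers stand for stronger inhibition and higher numbers for weaker inhibition:
- compound 1 `CC(CCO)n1cnc2c(Cl)ncnc21`: > 50000 nM (a limit)
- compound 2 `CCCCCCCC(CCO)n1cnc2c(N)ncnc21`: > 50000 nM (a limit)
- compound 3 `CCCCCCCCC(CCO)n1cnc2c(Cl)ncnc21`: 1650 nM

Only compound 3 reads as a number. Compound 1 and compound 2 stand at the limit of > 50000 nM in this assay, at which 2 of the 3 values shown sit. Compound 4 `CCCCCCCCC(CCO)n1cnc2c(N)ncnc21` differs from compound 3 by one group: amino in place of chloro on an aromatic carbon. Among the compounds with values here, the only measured step, an at least 30-fold lower number from compound 1 to compound 3 (1.48 log units; beyond the scatter), is large but lies in the chain, not at this aromatic carbon, so it sets no size for the swap. Compound 2 carries the same amino group, and its > 50000 nM is a limit, which is the ground for expecting weaker inhibition here. In this assay the expected change is a sizeable rise, estimated as a 12-fold higher number from compound 3 to compound 4 (1.08 log units; beyond the scatter). For compound 4 the estimate is 20000 nM, with an expected range of 5000 nM to 50000 nM.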

Compound 4, half-maximal inhibitory concentration: 11600 nM
Estimate against measurement, compound 4: 1.7-fold (0.24 log units) above; measured number inside the range.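

The amino group in place of chloro on this aromatic carbon now has a measured size in this assay: a 7.0-fold higher number from compound 3 to compound 4 (0.85 log units; beyond the scatter). With the amino group held, methyl in place of hydrogen on a saturated chain carbon, eight bonds along the chain from an aromatic nitrogen, gives an at least 4.3-fold lower number from compound 2 to compound 4 (0.63 log units; beyond the scatter), so the chain still counts among the amino compounds. That step starts from a limit of the assay, not a number: the limit of > 50000 nM in this assay, at which 2 of the 4 values shown sit.

Open, on these data alone, is whether a methylamino or a methoxy group on this aromatic carbon shifts the number, and whether a longer chain lowers it further.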